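A Larger Ring Attached to the Sulfur

This account rests on a few compounds, and the source may have more. Where it says the series, first, only, none or still open, it means among the compounds named here.

Going by the values given here, compound 1 `Cc1nnc(SCC(=O)N/N=c2/scc(-c3ccccc3)n2-c2ccccc2)s1` gives 65.9% in a functional assay on C6 cells (Rattus norvegicus) for cytotoxicity, read by MTT assay, with a stated time of 24 h, tested at 25 ug/mL (on this read-out lower numbers stand for a stronger effect and higher numbers for a weaker effect at the one concentration tested), the higher of the two numbers measured so far, so it shows the weaker effect. Compound 2 `COc1ccc(-c2cs/c(=N/NC(=O)CSc3nnc(C)s3)n2-c2ccccc2)cc1` gives 42.6% in this assay; the step of a number 23.3 percentage points lower from compound 1 to compound 2 (beyond the scatter) goes with methoxy in place of hydrogen on an aromatic carbon. Compound 3 `O=C(CSc1nnnn1-c1ccccc1)N/N=c1/scc(-c2ccccc2)n1-c1ccccc1` differs from compound 1 elsewhere: 1-phenyl-1H-tetrazol-5-yl in place of 5-methyl-1,3,4-thiadiazol-2-yl on a sulfur. Among the compounds with values here, no measured step touches this part of the molecule, so the available data offer no direct guide. Compound 3 is expected to move by a number 10.9 percentage points lower from compound 1 to compound 3 (beyond the scatter), toward a somewhat stronger effect. The estimate for compound 3 is 55%, ranging from 35% to 75%.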

Compound 3, a percentage reported as activity, at one concentration (the size of the read-out at that concentration, not a potency): 42.5%
Estimate against measurement, compound 3: 12.5 percentage points above; low and high end bracket the measured number.
By their numbers in this assay, from the lowest: compounds 3 and 2 (each within the scatter of the next); then compound 1.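

The group on the sulfur matters in this assay: 1-phenyl-1H-tetrazol-5-yl in place of 5-methyl-1,3,4-thiadiazol-2-yl gives a number 23.4 percentage points lower from compound 1 to compound 3 (beyond the scatter) and so a stronger effect. This position, untouched by the earlier step, therefore responds to change and accepts a larger group carrying an extra six-membered aromatic ring of carbon only. Nothing available explains the shift.

This single swap cannot separate the added phenyl ring from the change of five-membered ring. As far as these compounds go, how a plain methyl or an amine-bearing chain on the sulfur would behave remains open.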